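Replacing the acetamido group with a 4-aminophenyl group

The source may hold more compounds than are shown below. What is called first, only, known or untested is meant among the compounds shown, and "the series" means these compounds.

As far as these compounds go, compound 1 `CC(=O)NS(=O)(=O)c1ccc(N/C=C\C(=O)c2cc3ccccc3oc2=O)cc1` has no result reported in a functional assay on T47D cells (Homo sapiens) for cytotoxicity, read by sulforhodamine B assay, with a stated time of 48 h (on this read-out higher numbers stand for weaker inhibition and lower numbers for stronger inhibition), so its standing on these numbers is unknown. Two related compounds were measured: compound 2 `COc1cnc(NS(=O)(=O)c2ccc(N/C=C\C(=O)c3cc4ccccc4oc3=O)cc2)nc1` gives 8800 nM in this assay, and compound 3 `O=C(/C=C\Nc1ccc(S(=O)(=O)Nc2ccc3cn[nH]c3c2)cc1)c1cc2ccccc2oc1=O` gives 96500 nM. For the measured compounds named here, the single measured step, an 11-fold higher number from compound 2 to compound 3 (1.04 log units; beyond the scatter), changes a group on the sulfonamide nitrogen, not the sulfonyl sulfur itself. Compound 4 `Nc1ccc(S(=O)(=O)c2ccc(N/C=C\C(=O)c3cc4ccccc4oc3=O)cc2)cc1` differs from compound 1 at the sulfonyl sulfur: 4-aminophenyl in place of acetamido on a sulfonyl sulfur. Going by the values given here, no measured step shares this kind of change, and compound 1 has no number, so the size and direction of the step cannot be taken from the data. Compound 4 is therefore expected near the middle of the measured range, at an estimated 20000 nM, between 3000 nM and 150000 nM.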

Compound 4, half-maximal inhibitory concentration: 91900 nM
Beside the measured number, compound 4's estimate is 4.6-fold (0.66 log units) below it; the measured number falls inside the stated range.
By their numbers in this assay, from the lowest: compound 2; then compounds 4 and 3 (each within the scatter of the next).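

Putting 4-aminophenyl on the sulfonyl sulfur gives a 1.1-fold lower number from compound 3 to compound 4 (0.02 log units; within the scatter) in this assay and so stays within the scatter of the (1H-indazol-6-yl)amino group. Against (5-methoxypyrimidin-2-yl)amino, the same group gives a 10-fold higher number from compound 2 to compound 4 (1.02 log units; beyond the scatter) and so compound 2 stands apart from both others. A sulfonyl sulfur carrying an aromatic carbon rather than a sulfonamide nitrogen therefore does not, in itself, separate compound 4 from compound 3.

As far as these compounds go, compound 1 has no number and steps from it cannot be read; how a plain amino group on the sulfonyl sulfur would compare stays open. Nothing available here gives a reason for these differences.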